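Benzylcarbamoyl in place of benzyl on compound 3

A few compounds are considered here, and "the series" means these few. Any claim that something is new, unique, unknown or untested is made for them only; others in the source may bear on it.

Compound 1 `CC(=O)O[C@H]1CC[C@]2(C)[C@H](CC[C@@](C)(O)[C@H]2CC[C@@H]2C(C)=CC[C@H]3[C@H](CC[C@]3(C)O)C2(C)C)OC1(C)C`: 47900 nM
Compound 2 `CC1=CC[C@H]2[C@H](CC[C@]2(C)O)C(C)(C)[C@@H]1CC[C@H]1[C@]2(C)CC[C@H](OC(=O)c3ccc(Cl)cc3)C(C)(C)O[C@H]2CC[C@@]1(C)O`: 24100 nM
Compound 3 `CC1=CC[C@H]2[C@H](CC[C@]2(C)O)C(C)(C)[C@@H]1CC[C@H]1[C@]2(C)CC[C@H](OCc3ccccc3)C(C)(C)O[C@H]2CC[C@@]1(C)O`: > 50000 nM

In a functional assay on MCF7 cells (Homo sapiens) for antiproliferative activity, read by MTT assay, with a stated time of 72 h (on this read-out higher numbers stand for weaker inhibition and lower numbers for stronger inhibition), compound 3 is reported only as a limit (> 50000 nM). Compound 4 `CC1=CC[C@H]2[C@H](CC[C@]2(C)O)C(C)(C)[C@@H]1CC[C@H]1[C@]2(C)CC[C@H](OC(=O)NCc3ccccc3)C(C)(C)O[C@H]2CC[C@@]1(C)O` carries benzylcarbamoyl in place of benzyl on an oxygen on a saturated carbon. Three measured steps change the group on that oxygen. One is at least modest (an at least 2.0-fold higher number from compound 2 to compound 3 (0.31 log units; beyond the scatter)). The other two lie within the scatter (an at least 1.0-fold higher number from compound 1 to compound 3 (0.01 log units; that floor lies within the scatter) and a 2.0-fold lower number from compound 1 to compound 2 (0.30 log units; within the scatter)). Compound 4 regains a carbonyl on that oxygen, as compound 2 has (24100 nM), so a modest move to a lower number is expected in this assay rather than a large one. The expected step is modest (an at least 1.6-fold lower number from compound 3 to compound 4 (0.22 log units; that floor lies within the scatter)). Compound 4 is estimated at 30000 nM within a range from 14000 nM to 50000 nM (an expectation only).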

Compound 4, half-maximal inhibitory concentration: 24500 nM
Compound 4: the middle estimate sits 1.2-fold (0.09 log units) above what was measured; measured number inside the range.
By their numbers in this assay, from the lowest: compounds 2, 4 and 1 (each within the scatter of the next). At a limit, above all of these: compound 3.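

In this assay the change on this oxygen gives an at least 2.0-fold lower number from compound 3 to compound 4 (0.30 log units; that floor lies within the scatter) and so yields only a floor for the step. Compound 3 stands at a limit: the limit of > 50000 nM in this assay, at which 1 of the 4 values shown sits. The benzylamino group on the carbonyl carbon gives a 1.0-fold higher number from compound 2 to compound 4 (0.01 log units; within the scatter) against the 4-chlorophenyl group and a 2.0-fold lower number from compound 1 to compound 4 (0.29 log units; within the scatter) against the methyl group, so these three groups on the carbonyl are not told apart here. The compounds shown leave open what a free hydroxyl or a longer alkyl chain on this oxygen would give.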